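This account rests on a few compounds, and the source may have more. Where it says the series, first, only, none or still open, it means among the compounds named here.

Measured compounds:
compound 1 `Oc1ccc(-c2cc(-c3ccsc3)cc(-c3cccc(O)c3)n2)cc1`: 17.1%
compound 2 `Oc1cccc(-c2cc(-c3ccccn3)cc(-c3cccc(O)c3)n2)c1`: 8.3%

In an assay on isolated protein for inhibition of DNA topoisomerase 1 (Homo sapiens), with a stated time of 30 min, tested at 100 uM (a higher number here means a stronger effect of the compound at the concentration tested, a lower number a weaker effect), compound 2 gives 8.3%, and compound 1 gives 17.1%; the two numbers lie within the scatter of each other, so neither compound can be set apart from the other. Compound 3 `Oc1ccc(-c2cc(-c3ccccn3)cc(-c3cccc(O)c3)n2)cc1` differs from compound 2 in one place: 4-hydroxyphenyl in place of 3-hydroxyphenyl on an aromatic carbon. Among the compounds with values here, no measured pair shows this same change, so the size of its effect in this assay is not known; the expectation is a step of no more than the scatter, in either direction. Compound 3 is therefore estimated at 12%, between 0% and 30%, which would mean an expected step of a number 3.7 percentage points higher from compound 2 to compound 3 (within the scatter).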

Compound 3, a percentage reported as inhibition, at one concentration (the size of the read-out at that concentration, not a potency): 2.4%
The estimate for compound 3 lay 9.6 percentage points above the measured number; the range from low to high includes it.
By their numbers in this assay, from the lowest: compounds 3, 2 and 1 (each within the scatter of the next, the first and the last beyond it).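

In this assay, 4-hydroxyphenyl in place of 3-hydroxyphenyl next to the ring nitrogen gives a number 5.9 percentage points lower from compound 2 to compound 3 (within the scatter) and so does not separate the two groups at this position. Pyridin-2-yl in place of thiophen-3-yl gives a number 14.7 percentage points lower from compound 1 to compound 3 (beyond the scatter) and is the only step here that clears the scatter, though only modestly. Nothing available accounts for either step. Going by these compounds, whether an amine or a carboxylic acid at the position of the hydroxyphenyl group would shift the read-out stays open. So does how a methoxy group would compare with the hydroxyl.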